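This account rests on a few compounds, and the source may have more. Where it says the series, first, only, none or still open, it means among the compounds named here.

Working notes on the series. Compound 1 `O=C1O[C@H]([C@@H](O)Cn2cc(-c3ccc(Br)cc3)nn2)C(OCc2ccccc2)=C1OCc1ccccc1` and compound 2 `O=C1O[C@H]([C@@H](O)Cn2cc(-c3cccc(O)c3)nn2)C(OCc2ccccc2)=C1OCc1ccccc1` share one core and differ only in the group on the triazole. In an ADME assay on HFF cells (Homo sapiens) for cytotoxicity, read by MTT assay, with a stated time of 72 h (a lower number here means a stronger inhibitor, a higher number a weaker inhibitor), compound 1 gives 5100 nM, while compound 2 gives 39000 nM; the change between them reads a 7.6-fold higher number from compound 1 to compound 2 (0.88 log units; beyond the scatter). Within these two numbers compound 2 stands highest, with compound 1 as its only neighbour, separated by that step. Compound 3 `CCCCc1cn(C[C@H](O)[C@H]2OC(=O)C(OCc3ccccc3)=C2OCc2ccccc2)nn1` is the next member to be measured in this assay. Against compound 2 it shows (butyl in place of 3-hydroxyphenyl on an aromatic carbon). Going by the values given here, the only measured step that bears on this exchange is the one from compound 1 to compound 2, which also swaps the group on the triazole and was modest in size; no measured step removes the aromatic ring there altogether. For compound 3 the step of a 2.6-fold lower number from compound 2 to compound 3 (0.41 log units; beyond the scatter) is therefore expected, with a wide margin. Compound 3 is estimated at 15000 nM, within 5000 nM to 50000 nM.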

Compound 3, half-maximal inhibitory concentration: 26300 nM
Beside the measured number, compound 3's estimate is 1.8-fold (0.24 log units) below it, within the range that was stated.
By their numbers in this assay, from the lowest: compound 1; then compounds 3 and 2 (each within the scatter of the next).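

Removing the aromatic ring from the group on the triazole does not by itself separate the compounds in this assay: a 1.5-fold lower number from compound 2 to compound 3 (0.17 log units; within the scatter), so ring-free butyl and 3-hydroxyphenyl cannot be told apart here. The presence of a ring therefore does not set the number at this position, and compound 1 goes against any link between ring and reading, since a 5.2-fold higher number from compound 1 to compound 3 (0.71 log units; beyond the scatter), a gap beyond the scatter, even though 4-bromophenyl also carries a ring. Nothing available explains why compound 1 stands apart from compound 3 and compound 2.

The compounds shown leave open whether the bromine or the whole 4-bromophenyl group accounts for the separate reading of compound 1, which an unsubstituted phenyl would help settle. On these data alone, how a longer chain such as octyl, or a chain ending in an amine or a carboxylic acid, would read at this position also remains open.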